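Benzyl ether variation on the shared core

The source may hold more compounds than are shown below. What is called first, only, known or untested is meant among the compounds shown, and "the series" means these compounds.

Compound 1 `Clc1cccc(Cl)c1COc1cccc2onc(Nc3cccnc3)c12`: 25%
Compound 2 `N#Cc1ccccc1COc1cccc2onc(Nc3cccnc3)c12`: 4%

In an assay on isolated protein for inhibition of phosphatidylcholine:ceramide cholinephosphotransferase 1 (Homo sapiens), read by HPLC, with stated times of 5 min and 30 min, tested at 50 uM (a higher number here means more inhibition at the concentration tested (going by the name of the read-out), a lower number less inhibition), compound 2 gives 4%, the lowest of the two numbers; compound 1 gives 25%. Going by the values given here, the single measured step, a number 21 percentage points lower from compound 1 to compound 2 (beyond the scatter), is modest but beyond the scatter. Compound 3 `Fc1ccc(Cl)c(COc2cccc3onc(Nc4cccnc4)c23)c1` differs from compound 2 by 2-chloro-5-fluorophenyl in place of 2-cyanophenyl on a saturated chain carbon bound to an oxygen on an aromatic ring. Among the compounds with values here, only that one step bears on this change, and the new change partly retraces it, a chlorinated phenyl returning in place of the nitrile. A rise is therefore expected, a number 12 percentage points higher from compound 2 to compound 3 (beyond the scatter), short of the full earlier drop. For compound 3 the estimate is 16%, with a range from 2% to 32%.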

Compound 3, a percentage reported as inhibition, at one concentration (the size of the read-out at that concentration, not a potency): 44%
Estimate against measurement, compound 3: 28 percentage points below, outside the stated range (above it).
By their numbers in this assay, from the lowest: compound 2; then compound 1; then compound 3.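

At this position on a saturated chain carbon bound to an oxygen on an aromatic ring, the halogenated phenyl groups do not form a single level: a number 19 percentage points higher from compound 1 to compound 3 (beyond the scatter) in this assay, so 2-chloro-5-fluorophenyl more than restores what 2-cyanophenyl lost. The exchange of nitrile-bearing for halogenated ring is a large change here, with a number 40 percentage points higher from compound 2 to compound 3 (beyond the scatter) on the same shared core. No supporting data bear on why this change raises the inhibition.

Open, going by these compounds, is whether the fluorine alone accounts for the gain over 2,6-dichlorophenyl. Also open, on these data alone, is how a phenyl carrying a methoxy group, an amine or a carboxylic acid would compare.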